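Replacing the aryl on the carbonyl carbon with benzylamino

This account rests on a few compounds, and the source may have more. Where it says the series, first, only, none or still open, it means among the compounds named here.

Measured compounds:
- compound 1 `COc1ccc(C(=O)OC(CCN(C)C)c2ccc(Cl)cc2)cc1`: 2190 nM
- compound 2 `Cc1cccc(C(=O)OC(CCN(C)C)c2ccc(Cl)cc2)c1C`: 1150 nM
- compound 3 `Cc1ccc(C(=O)OC(CCN(C)C)c2ccc(Cl)cc2)cc1`: 2750 nM

The three compounds were examined in an assay on NIH3T3 cells with Urotensin-2 receptor (Homo sapiens) as the target; a lower number here means that less compound is needed, a higher number that more compound is needed for the effect. Compound 3 gives the highest of the three numbers. Its nearest neighbour is compound 1, and the two lie within the scatter of each other, so nothing can be said about their order. Compound 2 stands apart from compound 3: the step of a 2.4-fold higher number from compound 2 to compound 3 (0.38 log units; beyond the scatter) is modest but beyond the scatter.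

Compound 4 `CN(C)CCC(OC(=O)NCc1ccccc1)c1ccc(Cl)cc1` is not yet measured. It differs from compound 3 in one place: benzylamino in place of 4-methylphenyl on a carbonyl carbon.

For the measured compounds named here, none of the measured steps alters this position in the same way. The steps that do touch the group on the carbonyl carbon, a 1.9-fold lower number from compound 1 to compound 2 (0.28 log units; within the scatter) and a 2.4-fold higher number from compound 2 to compound 3 (0.38 log units; beyond the scatter), change only the pattern of small substituents on the phenyl and stay small to modest. The move to benzylamino is of a different kind, so those steps set only a rough scale. It is therefore expected that compound 4 lands near compound 3, with the step of a 1.1-fold higher number from compound 3 to compound 4 (0.04 log units; within the scatter) estimated as small and the direction open. Compound 4 is expected to give about 3000 nM in this assay, within a range of 800 nM to 12000 nM.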

Compound 4, half-maximal effective concentration: 2140 nM
For compound 4 the middle estimate is 1.4-fold (0.15 log units) above the measured one; the range from low to high includes it.
By their numbers in this assay, from the lowest: compounds 2, 4, 1 and 3 (each within the scatter of the next, the first and the last beyond it).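

In this assay, the carbonyl carbon accepts a change of a different kind from the earlier shifts of small substituents on the phenyl: benzylamino brings in a nitrogen and a hydrogen-bond donor that 4-methylphenyl lacks, yet the step of a 1.3-fold lower number from compound 3 to compound 4 (0.11 log units; within the scatter) stays within the scatter. The comparisons with the other two aryl groups read the same way, with a 1.9-fold higher number from compound 2 to compound 4 (0.27 log units; within the scatter) and a 1.0-fold lower number from compound 1 to compound 4 (0.01 log units; within the scatter), so compound 4 cannot be separated from any of the three esters, even though compound 2 and compound 3 lie beyond the scatter of each other. No measurement available here accounts for why benzylamino and these aryl groups give such similar numbers.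

From the compounds shown here alone, whether the hydrogen on the benzylamino nitrogen matters remains open, as does whether an N-methylbenzylamino, a phenethylamino or a plain butylamino on the carbonyl carbon would stay in the same range. All four compounds keep the rest of the core unchanged, so they also leave open how replacing the dimethylamino group with a pyrrolidine, for example, would act alongside benzylamino.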